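Compound 4: a larger group on an aromatic nitrogen

A few compounds are considered here, and "the series" means these few. Any claim that something is new, unique, unknown or untested is made for them only; others in the source may bear on it.

Compound 1 (`CN1C(=S)[C@@H](NC(=O)c2nc(Cc3ccccc3)n(C3CCC3)n2)COc2ccccc21`), compound 2 (`CN1C(=S)[C@@H](NC(=O)c2nc(Cc3ccccc3)n(C3CCCCCC3)n2)COc2ccccc21`) and compound 3 (`CN1C(=S)[C@@H](NC(=O)c2nc(Cc3ccccc3)n(CC3COC3)n2)COc2ccccc21`) share one core and differ only in the group on an aromatic nitrogen. In a toxicity assay on HT-29 cells (Homo sapiens) for cytotoxicity (on this read-out higher numbers stand for lower toxicity in this test and lower numbers for higher toxicity in this test), compound 1 gives > 100000 nM as a limit of the assay. Compound 2 gives > 100000 nM as a limit too. Compound 3 gives > 100000 nM as a limit as well. The whole picture is the limit of > 100000 nM in this assay, at which 3 of the 3 values shown sit, and nothing finer. Compound 4 (`CN1C(=S)[C@@H](NC(=O)c2nc(Cc3ccccc3)n(C3CCN(C(=O)OC(C)(C)C)C3)n2)COc2ccccc21`) brings a group of 12 heavy atoms (9 carbon, 1 nitrogen, 2 oxygen; one five-membered non-aromatic ring with 1 hetero atom) in place of a group of 5 heavy atoms (4 carbon, 1 oxygen; one four-membered non-aromatic ring with 1 hetero atom), on an aromatic nitrogen at that same place. The measured steps are a step that the two limits leave unreadable from compound 1 to compound 2 together with a step that the two limits leave unreadable from compound 1 to compound 3 and a step that the two limits leave unreadable from compound 2 to compound 3 and none offers a size to carry over. No change beyond the scatter is therefore expected in this assay with a number no higher from compound 3 to compound 4 (the limit leaves the size open) as the estimated step. The estimate for compound 4 is 100000 nM with an expected range from 30000 nM to 150000 nM and most likely another limit.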

Compound 4, half-maximal cytotoxic concentration: > 100000 nM
Compound 4: no number, only a limit (the forecaster's own chance of this, stated with the estimate: 85%); the middle value sits exactly at the limit.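

No step among compound 1, compound 2, compound 3 and compound 4 can be read, as all of them stop at the same limit: the limit of > 100000 nM in this assay, at which 4 of the 4 values shown sit.

As far as these compounds go, whether the group on the aromatic nitrogen changes the result in this assay at all, and by how much, stays open.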